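This account rests on a few compounds, and the source may have more. Where it says the series, first, only, none or still open, it means among the compounds named here.

Within the data shown here, compound 2 `COc1cc(Cl)cc(-c2nn(-c3cccc(NC(=O)Nc4cccc(C(F)(F)F)c4)c3)cc2-c2ccncc2)c1` gives -8% in a functional assay on NCI-H322M cells (Homo sapiens) for inhibition, read by sulforhodamine B assay, with a stated time of 48 h, tested at 100 uM (on this read-out lower numbers stand for a stronger effect and higher numbers for a weaker effect at the one concentration tested), the lower of the two numbers measured so far; its only neighbour, compound 1 `COc1cc(Cl)cc(-c2nn(-c3cccc(NC(=O)Nc4ccc(Cl)c(Cl)c4)c3)cc2-c2ccncc2)c1`, gives 3% in this assay. Among the measured compounds shown here, the single measured step, a number 11 percentage points lower from compound 1 to compound 2 (beyond the scatter), replaces one ring-bearing group with another on an amide-type nitrogen. Compound 3 `COc1cc(Cl)cc(-c2nn(-c3cccc(NC(=O)c4cccc(C(F)(F)F)c4)c3)cc2-c2ccncc2)c1` differs from compound 2 in a different way: 3-(trifluoromethyl)phenyl in place of (3-(trifluoromethyl)phenyl)amino on a carbonyl carbon. For the measured compounds named here, none of the measured steps touches the amide-type nitrogen itself, so no measured step bears directly on this change, and the data offer no guide to its size or direction. In the absence of such guidance, the step is expected to be a number 8 percentage points higher from compound 2 to compound 3 (within the scatter), that is, nothing that should stand out from the scatter. Compound 3 is therefore estimated to give 0% in this assay, with a plausible range from -15% to 15%.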

Compound 3, a percentage reported as activity, at one concentration (the size of the read-out at that concentration, not a potency): 75%
The estimate for compound 3 lay 75 percentage points below the measured number, outside the stated range (above it).
By their numbers in this assay, from the lowest: compound 2; then compound 1; then compound 3.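

Putting 3-(trifluoromethyl)phenyl in place of (3-(trifluoromethyl)phenyl)amino on a carbonyl carbon gives, in this assay, a number 83 percentage points higher from compound 2 to compound 3 (beyond the scatter), which means a much weaker effect at the one concentration tested. Set against the 3,4-dichlorophenyl compound, the same kind of change gives a number 72 percentage points higher from compound 1 to compound 3 (beyond the scatter), and both steps far exceed the earlier ring change, a number 11 percentage points lower from compound 1 to compound 2 (beyond the scatter), so among these compounds the amino nitrogen on the carbonyl carbon counts for more than the choice between these two ring groups. Nothing available explains why this nitrogen matters so much.

As far as these compounds go, it remains open whether a methylene group or an oxygen atom in place of that nitrogen would keep the stronger effect. From the compounds shown here alone, it is also open whether a methylamino link, which keeps the nitrogen but carries a methyl group on it, would do so.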